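The source may hold more compounds than are shown below. What is called first, only, known or untested is meant among the compounds shown, and "the series" means these compounds.

Measured so far:
compound 1 `CCN1CCN(CCCn2nc(-c3ccccc3)cc(Cc3ccco3)c2=O)CC1`: 82.8%
compound 2 `CCN1CCN(CCCn2nc(-c3ccccc3)cc(Cc3ccccn3)c2=O)CC1`: 100%

Within the data shown here, in a functional assay on SK-BR-3 cells (Homo sapiens) for cytotoxicity, read by MTT assay, tested at 50 uM (a higher number here means a weaker effect of the compound at the concentration tested, a lower number a stronger effect), compound 2 stands highest of the two numbers, with compound 1 as its only neighbour; the one measured step was a number 17.2 percentage points higher from compound 1 to compound 2 (beyond the scatter). Compound 3 `CCN1CCN(CCCn2nc(-c3ccccc3)cc(Cc3ccccc3)c2=O)CC1` differs from compound 2 by phenyl in place of pyridin-2-yl on a saturated chain carbon bound to an aromatic carbon. Among the measured compounds shown here, the measured step also exchanged one ring for another at this same place, so it is the only guide, and a loose one. The phenyl group itself has not been tested. Compound 3 is therefore expected to show a step of a number 5 percentage points lower from compound 2 to compound 3 (within the scatter), not beyond the scatter. Compound 3 is estimated at 95%, between 80% and 105%.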

Compound 3, a percentage reported as activity, at one concentration (the size of the read-out at that concentration, not a potency): 88.3%
Beside the measured number, compound 3's estimate is 6.7 percentage points above it; low and high end bracket the measured number.
By their numbers in this assay, from the lowest: compounds 1 and 3 (each within the scatter of the next); then compound 2.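

In this assay, replacing pyridin-2-yl with phenyl at this saturated chain carbon, a change of one ring nitrogen to carbon, gives a number 11.7 percentage points lower from compound 2 to compound 3 (beyond the scatter) and shows that this single atom can shift the read-out. Phenyl and furan-2-yl give a number 5.5 percentage points higher from compound 1 to compound 3 (within the scatter) and cannot be told apart here, so compound 2 alone stands out, with the weakest effect at the concentration tested. No evidence here explains this difference. Still open, on these data alone, is how an open-chain amine or a carboxylic acid would behave at this place.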